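Acetyl for Methoxy on the Fused Ring of Compound 2

This account rests on a few compounds, and the source may have more. Where it says the series, first, only, none or still open, it means among the compounds named here.

The study measured two compounds in a functional assay on HEK293 cells for agonist activity at Free fatty acid receptor 1 (Homo sapiens), read by fluorescence and calcium flux, with a stated time of 10 min; on this read-out lower numbers stand for smaller maximal responses and higher numbers for larger maximal responses. Compound 1 `O=C(O)CCc1ccc(NCC2COc3ccc(Cl)cc3O2)cc1F` gives 69% in this assay, while compound 2 `CC#C[C@@H](CC(=O)O)c1ccc(OC[C@H]2COc3ccc(OC)cc3O2)cc1` gives 91%. Compound 2 therefore stands highest of the two numbers; its nearest neighbour is compound 1, which lies lower by a gap that exceeds the usual scatter. Going by the values given here, no pair of measured compounds differs in only one place, so no single-change step is available.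

Compound 3 `CC#C[C@@H](CC(=O)O)c1ccc(OC[C@H]2COc3ccc(C(C)=O)cc3O2)cc1` is yet to be measured in this assay. It differs from compound 2 in one place: acetyl in place of methoxy on an aromatic carbon. Among the compounds with values here, since no measured pair shows what such a change does, the expectation rests on the high response of compound 2 at 91% alone. The step from compound 2 to compound 3 is expected to be a number 3 percentage points lower from compound 2 to compound 3 (within the scatter), that is, nothing beyond the scatter. Compound 3 is accordingly estimated at 88%, with a range from 70% to 100%.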

Compound 3, largest response reached (Emax), in percent of the reference or control that the assay uses: 51%
For compound 3 the middle estimate is 37 percentage points above the measured one, outside the stated range (below it).
By their numbers in this assay, from the lowest: compound 3; then compound 1; then compound 2.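

In this assay, the change from methoxy to acetyl on this aromatic carbon is a number 40 percentage points lower from compound 2 to compound 3 (beyond the scatter) and is large, so the largest response reached depends on which group sits here. The earlier compounds shown here could not show this, since no measured pair differed in one place, and the hydrogen-bond donor and acceptor counts of the two groups are the same, so those counts do not separate them. Nothing measured here explains the drop.

With a single change at this carbon, the compounds shown do not tell whether the carbonyl of acetyl or its extra carbon matters more. They also leave open how a nitrile, an amide or a hydroxyl on the same carbon would compare with methoxy and acetyl.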